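The compounds below may be only part of what the source reports. "The series", "measured", "known", "first", "only" and "open" are said of these compounds alone.

Working notes on the series. In a functional assay on CHO-K1 cells for antagonist activity at prostaglandin E2 receptor EP1 subtype (Homo sapiens), read by FLIPR and calcium flux (on this read-out higher numbers stand for weaker inhibition and lower numbers for stronger inhibition), compound 1 `CCc1ccccc1N(CC(=O)NCc1ccc(Br)cc1)S(=O)(=O)c1ccc(C)cc1` gives 22.9 nM. Compound 2 `Cc1ccc(S(=O)(=O)N(CC(=O)NCc2ccc(Cl)cc2)c2cccnc2C)cc1` in this assay gives 676 nM. Compound 3 `Cc1ccc(S(=O)(=O)N(CC(=O)NCc2ccc(Cl)cc2)c2ncccc2C)cc1` in this assay is reported only as a limit, < 1450 nM, not as a number. The step that the limit leaves unreadable from compound 2 to compound 3 cannot be sized because the limit of < 1450 nM in this assay, at which 1 of the 3 values shown sits, applies to compound 3. Compound 1 and compound 2 differ in more than one place, so only their two values stand side by side without a readable single step.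

Compound 4 `CCn1nccc1N(CC(=O)NCc1ccc(Cl)cc1)S(=O)(=O)c1ccc(C)cc1` is not yet measured. Relative to compound 3 the change is 1-ethyl-1H-pyrazol-5-yl in place of 3-methylpyridin-2-yl on a sulfonamide nitrogen. Within the data shown here, no measured step bears on this replacement; the only single-place step known, a step that the limit leaves unreadable from compound 2 to compound 3, gives no size, so the expected direction in this assay is open and the estimate rests on the spread between compound 2 and the limit of compound 3. Compound 4 is therefore expected near 300 nM, with a range from 60 nM to 1500 nM. The implied step that the limit leaves unreadable from compound 3 to compound 4 is expected to stay unreadable in size, within the wide range given.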

Compound 4, inhibition constant: 72.4 nM
Compound 4: middle estimate off by 4.1-fold (0.62 log units), on the high side; low and high end bracket the measured number.
By their numbers in this assay, from the lowest: compound 1; then compound 4; then compound 2.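

In this assay, among these compounds, the change to 1-ethyl-1H-pyrazol-5-yl on a sulfonamide nitrogen gives a 9.3-fold lower number from compound 2 to compound 4 (0.97 log units; beyond the scatter) and is the first readable single-place step at this position. The number at this position is therefore not tied to a six-membered aromatic ring: a five-membered aromatic ring with 2 hetero atoms gives the lower number of this pair. Compound 3 stands only as a limit, and its step to the pyrazole cannot be read because of that: the limit of < 1450 nM in this assay, at which 1 of the 4 values shown sits.

Going by these compounds, whether the ring or its ethyl group carries the step stays open, and so does how a longer chain or an amine on that ring would read. The compounds shown also do not separate the bromine of compound 1 from the chlorine of the others on the benzyl group.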